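A few compounds are considered here, and "the series" means these few. Any claim that something is new, unique, unknown or untested is made for them only; others in the source may bear on it.

Measured compounds in an ADME assay on Caco-2 cells (Homo sapiens) for permeability, read by LC-MS, in the apical to basolateral direction, with a stated time of 60 min, at pH 6.5; a lower number here means that the compound crosses the layer more slowly, a higher number that the compound crosses the layer faster:
- compound 1 `O=C(NCc1cc(Cl)ccc1-n1cnnn1)[C@@H]1[C@H]2C[C@H]2CN1C(=O)[C@H](O)c1ccccc1`: compound 1 gives 12 10^-6 cm/s
- compound 2 `O=C(NCc1cc(Cl)ccc1-n1cnnn1)[C@@H]1C[C@H]2C[C@H]2N1C(=O)[C@H](O)c1ccccc1`: compound 2 gives 17 10^-6 cm/s
- compound 3 `CC(C)(C)C[C@@H](O)C(=O)N1C[C@@H]2C[C@@H]2[C@H]1C(=O)NCc1cc(Cl)ccc1-n1cnnn1`: compound 3 gives 25 10^-6 cm/s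

Compound 1 and compound 2 share the same atoms joined differently; the difference between the two cores is not broken down here. Their values in this assay lie within the scatter of each other, so no order between them is claimed.

From compound 1 to compound 3 the change is neopentyl in place of phenyl on a saturated chain carbon bound to a carbonyl carbon and an oxygen on a saturated carbon, and the step was a 2.1-fold higher number from compound 1 to compound 3 (0.32 log units; beyond the scatter). Going by the values given here, this is the one change with a measured step in the set.

Compound 4 `CC(C)(C)C[C@@H](O)C(=O)N1[C@@H]2C[C@@H]2C[C@H]1C(=O)NCc1cc(Cl)ccc1-n1cnnn1` is not yet measured. Relative to compound 2 it carries the same change, (neopentyl in place of phenyl on a saturated chain carbon bound to a carbonyl carbon and an oxygen on a saturated carbon), on the core of compound 2; the place lines read alike, so this is the same kind of change on a different core.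

The expectation for compound 4 in this assay rests on the step seen for compound 3, a 2.1-fold higher number from compound 1 to compound 3 (0.32 log units; beyond the scatter), applied to the value of compound 2, 17 10^-6 cm/s. Among the compounds with values here, the expected step is a 2.1-fold higher number from compound 2 to compound 4 (0.31 log units; beyond the scatter), with the proviso that the change is measured on only one core so far.

Compound 4 is expected to give about 35 10^-6 cm/s, estimated to fall between 20 10^-6 cm/s and 60 10^-6 cm/s.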

Compound 4, apparent permeability: 24 10^-6 cm/s
For compound 4 the middle estimate is 1.5-fold (0.16 log units) above the measured one; low and high end bracket the measured number.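

In this assay, neopentyl in place of phenyl on the core of compound 2 gives a 1.4-fold higher number from compound 2 to compound 4 (0.15 log units; within the scatter), so on this core the change cannot be told apart from repeat-measurement noise. Set beside the earlier step, the two cores do not separate for this change: the same change on two cores in this assay, a 2.1-fold higher number (0.32 log units; beyond the scatter) from compound 1 to compound 3 and a 1.4-fold higher number (0.15 log units; within the scatter) from compound 2 to compound 4, 1.5-fold (0.17 log units) apart, within the scatter of two such steps

Going by these compounds alone, the two steps are therefore compatible with the change carrying over from one core to the other, but with a single pair on each core they do not establish that its size is the same on both, and only the step on the core of compound 1 lies beyond the scatter.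

The compounds shown leave open how other groups at this place would read in this assay, such as a longer chain, a cyclohexyl ring, or a chain ending in an amine or a carboxylic acid. They also leave open whether the same exchange of phenyl for neopentyl would give a comparable step on any third core.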